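Notes on the shared core: compound 3 to compound 4

A few compounds are considered here, and "the series" means these few. Any claim that something is new, unique, unknown or untested is made for them only; others in the source may bear on it.

Three members of the set have been run in a functional assay on A549 cells (Homo sapiens) for antiproliferative activity, read by MTT assay, with a stated time of 12 h; a higher number here means a weaker inhibitor, a lower number a stronger inhibitor. Compound 1 `COc1ccc2c(=O)cc(/C=C/c3ccc(OC(F)(F)F)cc3)oc2c1` sits at a limit of this assay, giving > 40000 nM. Compound 2 `COc1cc(/C=C/c2cc(=O)c3c(OC)cc(OC)cc3o2)cc(OC)c1` returns a number in this assay, 15600 nM. Compound 3 `COc1cc(OC)c2c(=O)cc(/C=C/c3ccc(Br)cc3)oc2c1` is again at a limit, reported as > 40000 nM. Compound 3 therefore stands with the larger part of the set, at the limit of > 40000 nM in this assay, at which 2 of the 3 values shown sit. Only compound 2 yields a value, and that value lies far from the strong end of this assay. Among the measured compounds shown here, no pair of measured compounds differs in a single place, so no measured step can be quoted, and nothing measured here touches a pyridin-4-yl group.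

Compound 4 `COc1cc(OC)c2c(=O)cc(/C=C/c3ccncc3)oc2c1` is the next candidate. Relative to compound 3 the change is pyridin-4-yl in place of 4-bromophenyl on a double-bonded chain carbon bound to a double-bonded chain carbon. For the measured compounds named here, the one compound with a number, compound 2, carries a different substitution on both rings, so it gives no direct guide. For compound 4 the expected step is an at least 1.3-fold lower number from compound 3 to compound 4 (0.12 log units; that floor lies within the scatter), small and within the scatter if any. Compound 4 is estimated at 30000 nM, with a range from 8000 nM to 80000 nM, and a fair chance that this assay once more reports only a limit.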

Compound 4, half-maximal inhibitory concentration: > 40000 nM
Compound 4: only a limit was reported (the forecaster's own chance of this, stated with the estimate: 50%); middle value at least 1.3-fold (0.12 log units) from the limit.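

In this assay compound 3 and compound 4 both stand only at a limit, so no step between them can be read: the limit of > 40000 nM in this assay, at which 3 of the 4 values shown sit.

Among the compounds shown here, still open is whether pyridin-4-yl in place of 4-bromophenyl shifts activity at all, and which features of compound 2, the only compound with a number, set it apart from the others.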